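Chloro for methyl on the aryl ring of compound 1

The source may report more compounds than this note shows. Statements on the series, on what has been measured and on what is new or still open speak of the compounds shown alone.

Going by the values given here, compound 1 `Cc1ccccc1-n1cc(CN2C(=O)C[C@@H]3CC[C@@]2(C)C3(C)C)nn1` is one of three compounds measured in a functional assay on OVCAR-3 cells (Homo sapiens) for inhibition, read by MTT assay, with a stated time of 24 h (a lower number here means a stronger inhibitor, a higher number a weaker inhibitor), where compound 1 gives 150 nM. Compound 2 `CC1(C)[C@H]2CC[C@]1(C)N(Cc1cn(-c3ccccc3C#N)nn1)C(=O)C2` gives 110 nM and compound 3 `CC1(C)[C@H]2CC[C@]1(C)N(Cc1cn(-c3ccc(F)cc3)nn1)C(=O)C2` gives 200 nM; the steps of a 1.4-fold lower number from compound 1 to compound 2 (0.13 log units; within the scatter), a 1.3-fold higher number from compound 1 to compound 3 (0.12 log units; within the scatter) and a 1.8-fold higher number from compound 2 to compound 3 (0.26 log units; within the scatter) are all within the scatter. Compound 4 `CC1(C)[C@H]2CC[C@]1(C)N(Cc1cn(-c3ccccc3Cl)nn1)C(=O)C2` differs from compound 1 by chloro in place of methyl on an aromatic carbon. The step that bears most on it, a 1.4-fold lower number from compound 1 to compound 2 (0.13 log units; within the scatter), exchanges the same methyl on the same aromatic carbon and stays within the scatter, so no step beyond the scatter is expected for a 1.1-fold lower number from compound 1 to compound 4 (0.03 log units; within the scatter) in this assay. Compound 4 is therefore expected to give about 140 nM, between 70 nM and 280 nM.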

Compound 4, half-maximal inhibitory concentration: 40 nM
Compound 4: middle estimate off by 3.5-fold (0.54 log units), on the high side; the measured number lies below the stated range.
By their numbers in this assay, from the lowest: compound 4; then compounds 2, 1 and 3 (each within the scatter of the next).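

Going by these compounds alone, at this aromatic carbon, the swap from methyl to nitrile had stayed within the scatter, whereas chloro gives the first change here that goes beyond it, in this assay (a 3.8-fold lower number from compound 1 to compound 4 (0.57 log units; beyond the scatter)). Chloro also separates from nitrile on the same carbon (a 2.8-fold lower number from compound 2 to compound 4 (0.44 log units; beyond the scatter)) and 2-chlorophenyl from 4-fluorophenyl (a 5.0-fold lower number from compound 3 to compound 4 (0.70 log units; beyond the scatter)), so compound 4 is the most potent of the four. Nothing measured here accounts for this difference.

Still open, as far as these compounds go, is whether bromo, methoxy or an amine on this carbon would match chloro. From the compounds shown here alone, it is also open whether chloro elsewhere on the ring would give a similar number.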